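The compounds below may be only part of what the source reports. "The series", "measured", "known", "first", "only" and "open" are said of these compounds alone.

Working notes on the series.

The read-out throughout is a functional assay on DLD-1 cells (Homo sapiens) for antiproliferative activity, read by trypan blue exclusion; on this read-out lower numbers stand for stronger inhibition and higher numbers for weaker inhibition. Within the data shown here, compound 1, `COc1cc(OC)c(/C=C/S(=O)(=O)Cc2ccc(C#N)cc2)c(OC)c1`, is the one member for which this assay returns a number: in this assay compound 1 gives 20000 nM. Compound 2, `COc1ccc(CS(=O)(=O)/C=C/c2ccc(N)cc2)cc1`, reaches only the limit of the assay, and in this assay compound 2 gives > 20000 nM, which is a limit rather than a number. Compound 3, `COc1ccc(CS(=O)(=O)/C=C/c2cc(OC)c(OC)c(OC)c2)cc1`, likewise reaches only the limit, and in this assay compound 3 gives > 20000 nM, again a limit and not a number. Among the measured compounds shown here, compound 1 therefore stands as the sole measured value of the set, with the two other entries sitting at the limit of > 20000 nM in this assay, at which 2 of the 3 values shown sit. For the measured compounds named here, no pair of compounds here differs in a single place, so no measured step is available to size any change.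

Compound 4, `COc1cc(OC)c(/C=C/S(=O)(=O)Cc2ccc(OC(F)(F)F)cc2)c(OC)c1`, is not yet measured. Against compound 1 it carries trifluoromethoxy in place of cyano on an aromatic carbon, that is, trifluoromethoxy in place of cyano on an aromatic carbon. Going by the values given here, with no measured step to lean on, the expectation is a step of no change at the digits printed from compound 1 to compound 4 (within the scatter) in this assay, not beyond the scatter in either direction. The value estimated for compound 4 in this assay is 20000 nM, with a range from 8000 nM to 50000 nM, and a fair chance that the assay again reports only a limit.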

Compound 4, half-maximal inhibitory concentration: 4000 nM
Estimate against measurement, compound 4: 5.0-fold (0.70 log units) above; the whole stated range lies above it.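

In this assay, among these compounds, this is the first measured change: a 5.0-fold lower number from compound 1 to compound 4 (0.70 log units; beyond the scatter), with trifluoromethoxy in place of cyano on an aromatic carbon, para to a large group. On the core of compound 1, the number therefore responds to the group at this position and can move toward stronger inhibition, which compounds 1, 2 and 3 could not show on their own, as no two of them differ in a single place. Nothing measured here gives a property of either group that would account for the step.

Among the compounds shown, this position carries only these two groups, so it remains open whether an amine, a carboxylic acid or a chlorine atom there would give a number nearer that of compound 1 or that of compound 4. From the compounds shown here alone, compounds 2 and 3 differ from compound 4 in more than one place, so whether the step carries over to their cores also remains open.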